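From methylcarbamoyl to dimethylcarbamoyl on the shared core

This account rests on a few compounds, and the source may have more. Where it says the series, first, only, none or still open, it means among the compounds named here.

In a functional assay on NTUB1 cells (Homo sapiens) for cytotoxicity, read by MTT assay, with a stated time of 72 h (a higher number here means a weaker inhibitor, a lower number a stronger inhibitor), compound 1 (`COc1ccc(OC)c(C(=O)/C=C/c2ccc(C(=O)O)cc2)c1`) gives 5700 nM, compound 2 (`COC(=O)c1ccc(/C=C/C(=O)c2cc(OC)ccc2OC)cc1`) gives 3510 nM and compound 3 (`CNC(=O)c1ccc(/C=C/C(=O)c2cc(OC)ccc2OC)cc1`) gives 2200 nM. Within the data shown here, compound 3 carries the lowest number of the three, but it stands clear of only one neighbour. The two steps reaching it are a 2.6-fold lower number from compound 1 to compound 3 (0.41 log units; beyond the scatter) and a 1.6-fold lower number from compound 2 to compound 3 (0.20 log units; within the scatter).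

Compound 4 (`COc1ccc(OC)c(C(=O)/C=C/c2ccc(C(=O)N(C)C)cc2)c1`) differs from compound 3 by one change: methyl in place of hydrogen on an amide-type nitrogen. This is methyl in place of hydrogen on an amide-type nitrogen, so methylcarbamoyl becomes dimethylcarbamoyl. Among the measured compounds shown here, no measured pair makes this exact change. For the measured compounds named here, the only measured swap of methyl for hydrogen, on oxygen rather than nitrogen, is a 1.6-fold lower number from compound 1 to compound 2 (0.21 log units; within the scatter). The swap of methoxy for methylamino on the same carbonyl carbon, a 1.6-fold lower number from compound 2 to compound 3 (0.20 log units; within the scatter), is equally small. Only the replacement of hydroxy by methylamino, a 2.6-fold lower number from compound 1 to compound 3 (0.41 log units; beyond the scatter), goes further, and that is a larger change than the one at hand.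

On these three steps, no shift beyond the scatter is expected in this assay, and no direction is favoured. The expected step is a 1.2-fold higher number from compound 3 to compound 4 (0.07 log units; within the scatter). The estimate for compound 4 is 2600 nM, with an expected range of 1100 nM to 5500 nM.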

Compound 4, half-maximal inhibitory concentration: 3890 nM
Compound 4: the middle estimate sits 1.5-fold (0.17 log units) below what was measured, within the range that was stated.
By their numbers in this assay, from the lowest: compounds 3, 2, 4 and 1 (each within the scatter of the next, the first and the last beyond it).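

In this assay, the first step measured on the amide-type nitrogen itself, replacing the amide hydrogen with methyl (a 1.8-fold higher number from compound 3 to compound 4 (0.25 log units; within the scatter)), stays within the scatter, so this position accepts a second methyl without a separable shift in the number. Among these compounds, with dimethylamino on the carbonyl carbon, compound 4 also cannot be separated from the methoxy or hydroxy compounds (a 1.1-fold higher number from compound 2 to compound 4 (0.04 log units; within the scatter); a 1.5-fold lower number from compound 1 to compound 4 (0.17 log units; within the scatter)), whereas methylamino on that carbon gave the one earlier step beyond the scatter (a 2.6-fold lower number from compound 1 to compound 3 (0.41 log units; beyond the scatter)), and that separation from compound 1 does not carry over to dimethylamino. No measurement on hand accounts for any of these steps.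

Still open, going by these compounds, is whether an unsubstituted carboxamide, with two hydrogens on that nitrogen, or a longer chain such as ethyl or propyl there would move the number beyond the scatter of compound 3. Equally open, on these data alone, is whether a piperidine amide, or a chain ending in a hydroxyl group or an amine on the same nitrogen, would stand clear of compound 1 as compound 3 does.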